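Shortening the Amide Chain on a Kinase Inhibitor Core

A few compounds are considered here, and "the series" means these few. Any claim that something is new, unique, unknown or untested is made for them only; others in the source may bear on it.

Measured so far:
compound 1 `CCC1C(=O)N(C)c2cnc(-n3ccc4cc(F)ccc43)nc2N1c1ccn(C)n1`: 1500 nM
compound 2 `CCCCNC(=O)c1ccc2c(ccn2-c2ncc3c(n2)N(c2ccn(C)n2)C(CC)C(=O)N3C)c1`: 159 nM

In an assay for inhibition of serine/threonine-protein kinase PLK2 (Homo sapiens), read by FRET and Z'-LYTE, with a stated time of 1 h (a higher number here means a weaker inhibitor, a lower number a stronger inhibitor), compound 1 gives 1500 nM and compound 2 gives 159 nM. Among the measured compounds shown here, compound 2 therefore stands lowest of the two numbers, the only other one being compound 1. For the measured compounds named here, the single measured step, a 9.4-fold lower number from compound 1 to compound 2 (0.97 log units; beyond the scatter), came with butylcarbamoyl in place of fluoro on an aromatic carbon, so the amide group itself is tied to the stronger inhibition.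

Compound 3 `CCNC(=O)c1ccc2c(ccn2-c2ncc3c(n2)N(c2ccn(C)n2)C(CC)C(=O)N3C)c1` differs from compound 2 by hydrogen in place of ethyl on a saturated chain carbon, two bonds along the chain from an amide-type nitrogen. The amide stays; only the chain on its nitrogen shortens. The step of a 9.4-fold lower number from compound 1 to compound 2 (0.97 log units; beyond the scatter) bears on this only loosely, since it added the whole group rather than trimming its chain. Going by the values given here, no measured step probes chain length, so no change beyond the scatter is expected in this assay. Compound 3 is expected to give 220 nM, with a range from 100 nM to 500 nM. The expected step of a 1.4-fold higher number from compound 2 to compound 3 (0.14 log units; within the scatter) is small.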

Compound 3, half-maximal inhibitory concentration: 243 nM
For compound 3 the middle estimate is 1.1-fold (0.04 log units) below the measured one; the measured number falls inside the stated range.
By their numbers in this assay, from the lowest: compounds 2 and 3 (each within the scatter of the next); then compound 1.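

In this assay, going from butylamino to ethylamino leaves the two compounds within the usual scatter of each other (a 1.5-fold higher number from compound 2 to compound 3 (0.18 log units; within the scatter)), so this position tolerates the loss of the ethyl end of the chain and the two chain lengths cannot be told apart. Ethylcarbamoyl in place of fluoro still gives a step beyond the scatter (a 6.2-fold lower number from compound 1 to compound 3 (0.79 log units; beyond the scatter)), which shows that the stronger inhibition seen with butylcarbamoyl does not require the full butyl chain. Nothing available here explains why the chain length matters so little.

From the compounds shown here alone, it remains open whether the chain can be shortened further, to a methyl or to the unsubstituted carboxamide, and whether a carboxylic acid could stand in place of the amide. A longer chain, or an amine at the end of the chain, also remains untested among the compounds shown.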